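Methoxy to hydroxy on the shared core: expected cytotoxicity

A few compounds are considered here, and "the series" means these few. Any claim that something is new, unique, unknown or untested is made for them only; others in the source may bear on it.

Measured so far:
compound 1 `COc1cc(C)cc(-c2nn(CC#N)cc2-c2ccnc(-c3ccc(N(C)C)cc3)c2)c1` — 14%
compound 2 `COc1cc(C)cc(-c2nn(CC#N)cc2-c2ccc(-c3cccc(C(C)=O)c3)nc2)c1` — 21%

In a functional assay on A549 cells (Homo sapiens) for cytotoxicity, read by sulforhodamine B assay, with a stated time of 48 h, tested at 1 uM (on this read-out higher numbers stand for a weaker effect at the one concentration tested and lower numbers for a stronger effect), compound 1 gives 14% and stands lowest of the two numbers, but compound 2 gives 21%, a gap within the usual scatter, so no order between the two is claimed.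

Compound 3 `Cc1cc(O)cc(-c2nn(CC#N)cc2-c2ccnc(-c3ccc(N(C)C)cc3)c2)c1` differs from compound 1 by hydrogen in place of methyl on an oxygen on an aromatic ring. Within the data shown here, no measured pair shows this change, so the expected step in this assay is small, in either direction, and not beyond the scatter. Compound 3 is expected to give 20%, with a range of 5% to 45%. The estimated step is a number 6 percentage points higher from compound 1 to compound 3 (within the scatter).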

Compound 3, a percentage reported as activity, at one concentration (the size of the read-out at that concentration, not a potency): 23%
Beside the measured number, compound 3's estimate is 3 percentage points below it, within the range that was stated.
By their numbers in this assay, from the lowest: compounds 1, 2 and 3 (each within the scatter of the next).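

Methoxy to hydroxy on the 3-methoxy-5-methylphenyl group is the first single change that can be read in this series: in this assay, the step is a number 9 percentage points higher from compound 1 to compound 3 (within the scatter). Hydrogen in place of methyl on this oxygen therefore gives no step beyond the scatter, and no order between the two compounds is claimed. No measurement at hand bears on the reason for this result.

Still open, from the compounds shown here alone, is how an amine or an ethoxy group at this place would read. Also open, going by these compounds, is whether the same change gives a similar step on the core of compound 2.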